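This account rests on a few compounds, and the source may have more. Where it says the series, first, only, none or still open, it means among the compounds named here.

In an assay on FRT cells for positive allosteric modulation of Cystic fibrosis transmembrane conductance regulator variant N1303K (Homo sapiens), in the presence of a further agent that is not named here (on this read-out higher numbers stand for an effect only at larger amounts of compound and lower numbers for an effect already at smaller amounts), compound 3 `COc1ccc2[nH]c3c(c2c1)CCNC31CCN(Cc2cc(F)ccc2F)CC1` gives 11100 nM, the highest of the three numbers, although the step of a 1.6-fold higher number from compound 1 to compound 3 (0.19 log units; within the scatter) stays within the scatter. Compound 1 `COc1ccc2[nH]c3c(c2c1)CCNC31CCN(Cc2cc(Cl)ccc2[N+](=O)[O-])CC1` gives 7100 nM. Compound 2 `COc1ccc2[nH]c3c(c2c1)CCNC31CCN(Cc2cc(F)cc(Cl)c2)CC1` gives 2500 nM, and the step of a 4.4-fold higher number from compound 2 to compound 3 (0.65 log units; beyond the scatter) lies beyond the scatter. Compound 4 `COc1ccc2[nH]c3c(c2c1)CCNC31CCN(Cc2cc(F)c(F)c(F)c2)CC1` differs from compound 3 in one place: 3,4,5-trifluorophenyl in place of 2,5-difluorophenyl on a saturated chain carbon bound to an amine nitrogen in a ring. All measured steps swap one such aryl group for another, and the swap a 2.8-fold lower number from compound 1 to compound 2 (0.45 log units; beyond the scatter) shows such a change can shift the number modestly. Among the measured compounds shown here, compound 2 stands apart because its 2500 nM is the only number clearly separated from compound 3. For compound 4 the expected step is a 2.2-fold lower number from compound 3 to compound 4 (0.35 log units; beyond the scatter), a modest fall. Compound 4 is therefore estimated at 5000 nM, within a range from 2000 nM to 14000 nM.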

Compound 4, half-maximal effective concentration: 2600 nM
For compound 4 the middle estimate is 1.9-fold (0.28 log units) above the measured one, within the range that was stated.
By their numbers in this assay, from the lowest: compounds 2 and 4 (each within the scatter of the next); then compounds 1 and 3 (each within the scatter of the next).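

At this saturated chain carbon bound to an amine nitrogen in a ring, an aryl group carrying only fluorine can match one carrying chlorine (a 1.0-fold higher number from compound 2 to compound 4 (0.02 log units; within the scatter)), a step within the scatter, while the other two steps lie beyond it (a 4.3-fold lower number from compound 3 to compound 4 (0.63 log units; beyond the scatter); a 2.7-fold lower number from compound 1 to compound 4 (0.44 log units; beyond the scatter)). Compound 3 and compound 4 both carry only fluorine on this ring, so in this assay fluorine alone does not set the number. Nothing measured here explains this difference. Still open, as far as these compounds go, is how 3,5-difluorophenyl would compare, which would separate the third fluorine from the change in fluorine placement. Also open, from the compounds shown here alone, is whether a benzyl group carrying an amine or a carboxylic acid would fit this position.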